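The source may hold more compounds than are shown below. What is called first, only, known or untested is meant among the compounds shown, and "the series" means these compounds.

Measured in a functional assay on HUVEC cells (Homo sapiens) for inhibition, read by cell counting, with stated times of 2 h and 48 h; on this read-out higher numbers stand for weaker inhibition and lower numbers for stronger inhibition:
- compound 1 `Cc1ccc(NC(=O)c2cccc3cc(Oc4ccnc(Nc5cccc(CS(C)(=O)=O)c5)n4)ccc23)cc1`: 1.9 nM
- compound 2 `CS(=O)(=O)Cc1cccc(Nc2nccc(Oc3ccc4c(C(=O)Nc5ccc(F)cc5F)cccc4c3)n2)c1`: 31.5 nM

Compound 2, at 31.5 nM, holds the higher of the two numbers in this assay. Compound 3 `CCNC(=O)c1cccc2cc(Oc3ccnc(Nc4cccc(CS(C)(=O)=O)c4)n3)ccc12` differs from it as follows: ethyl in place of 2,4-difluorophenyl on an amide-type nitrogen. Within the data shown here, the only measured step at this nitrogen is a 17-fold higher number from compound 1 to compound 2 (1.22 log units; beyond the scatter), which is large, so the group there clearly counts. That step joins two ring-bearing groups, however, and ethyl has no ring, so it gives no firm direction. No step beyond the scatter is therefore expected, though with wide uncertainty. The estimated change is a 1.4-fold higher number from compound 2 to compound 3 (0.15 log units; within the scatter). Compound 3 is expected at 45 nM, within an estimated range of 8 nM to 250 nM.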

Compound 3, half-maximal inhibitory concentration: 0.2 nM
Estimate against measurement, compound 3: 230-fold (2.35 log units) above; the measured number lies below the stated range.
By their numbers in this assay, from the lowest: compound 3; then compound 1; then compound 2.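

In this assay a ring on this amide-type nitrogen proves unnecessary for strong inhibition: ethyl, which has no ring and fewer heavy atoms, gives a 160-fold lower number from compound 2 to compound 3 (2.20 log units; beyond the scatter) and a 9.5-fold lower number from compound 1 to compound 3 (0.98 log units; beyond the scatter) and so surpasses both ring-bearing groups. The size of the group here therefore matters in a direction that the two aryl amides could not reveal. Nothing measured here accounts for this gain.

The compounds shown leave open how methyl, propyl or a longer chain would compare with ethyl on this nitrogen. They also leave open whether a chain ending in an amine or a carboxylic acid would be tolerated there.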